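Swapping the Chain End: Carbamoyl to Pyrrolidinylmethyl

A few compounds are considered here, and "the series" means these few. Any claim that something is new, unique, unknown or untested is made for them only; others in the source may bear on it.

Compound 1 `Cn1ncc(Cl)c1-c1cc(C(=O)N[C@@H]2CN[C@H](CC(O)CO)C[C@H]2c2ccc(Cl)c(Cl)c2)oc1Cl` gives 3.79 nM in an assay for inhibition of RAC-alpha serine/threonine-protein kinase (Homo sapiens), read by HTRF, with a stated time of 1 h; a higher number here means a weaker inhibitor, a lower number a stronger inhibitor.
Compound 2 `Cn1ncc(Cl)c1-c1cc(C(=O)N[C@@H]2CN[C@H](CC(N)=O)C[C@H]2c2ccc(Cl)c(Cl)c2)oc1Cl` gives 3.24 nM in this assay.

Of the compounds shown here, two have been measured so far, and they differ only at the chain on the saturated ring carbon. The step of a 1.2-fold lower number from compound 1 to compound 2 (0.07 log units; within the scatter) shows that this exchange made no difference beyond the scatter. Compound 2 has the lower of the two numbers, but since it sits within the scatter of compound 1, neither can be called the stronger inhibitor on this evidence.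

Compound 3 `Cn1ncc(Cl)c1-c1cc(C(=O)N[C@@H]2CN[C@H](CCN3CCCC3)C[C@H]2c2ccc(Cl)c(Cl)c2)oc1Cl` continues at the same place on the chain: (pyrrolidin-1-yl)methyl in place of carbamoyl on a saturated chain carbon bound to a saturated ring carbon. Within the data shown here, the only measured step that bears on this change is the one from compound 1 to compound 2, which was flat, so the chain end at this position has so far been tolerant of exchange. On that single precedent, the expected step from compound 2 is a 1.2-fold higher number from compound 2 to compound 3 (0.09 log units; within the scatter), with no change beyond the scatter anticipated in this assay. Compound 3 is therefore expected to give 4 nM in this assay, estimated to fall between 1.5 nM and 12 nM.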

Compound 3, half-maximal inhibitory concentration: 6.41 nM
Estimate against measurement, compound 3: 1.6-fold (0.20 log units) below; measured number inside the range.
By their numbers in this assay, from the lowest: compounds 2, 1 and 3 (each within the scatter of the next).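

In this assay, (pyrrolidin-1-yl)methyl in place of carbamoyl gives a 2.0-fold higher number from compound 2 to compound 3 (0.30 log units; within the scatter), and the same group in place of 1,2-dihydroxyethyl gives a 1.7-fold higher number from compound 1 to compound 3 (0.23 log units; within the scatter), so neither exchange moves the number beyond the scatter. Compound 3 extends what the earlier pair showed: on a saturated chain carbon bound to a saturated ring carbon, the flat result now also covers a group with a five-membered non-aromatic ring, 6 heavy atoms against the 3 of carbamoyl, and 0 hydrogen-bond donors. Nothing measured here gives a reason for these numbers, so they describe the tolerance at this place without explaining it.

Going by these compounds, what remains open is whether a carboxylic acid, a morpholin-4-ylmethyl group or a longer chain carrying the pyrrolidine would also stay within the scatter of these three compounds at this place. The compounds shown also do not separate the ring from its nitrogen, a question that a cyclopentylmethyl group, with carbon atoms only, or an open-chain diethylaminomethyl group would address.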